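The source may hold more compounds than are shown below. What is called first, only, known or untested is meant among the compounds shown, and "the series" means these compounds.

Two compounds of a shared core carrying a benzylsulfanyl arm have been measured in a functional assay on MCF7 cells (Homo sapiens) for inhibition, read by MTT assay, with a stated time of 72 h; a lower number here means a stronger inhibitor, a higher number a weaker inhibitor. Compound 1, `Cc1cc(Nc2cc(-c3ccccc3)[nH]n2)n2nc(SCc3ccc(F)cc3)nc2n1`, gives 4020 nM in this assay. Compound 2, `Cc1cc(Nc2cc(-c3ccc(F)cc3)[nH]n2)n2nc(SCc3ccc(Br)cc3)nc2n1`, gives 4570 nM; compound 1 has the lower of the two numbers, but the two values lie within the scatter of each other, so neither can be called the stronger inhibitor. Compound 3, `COc1ccc(CSc2nc3nc(C)cc(Nc4cc(-c5ccccc5)[nH]n4)n3n2)cc1`, has not yet been measured. It differs from compound 1 in a single place: methoxy in place of fluoro on an aromatic carbon. Among the compounds with values here, no measured pair of compounds shows this exact change, so nothing here tells how large its effect would be. Within the data shown here, with no such step at hand, compound 3 is expected to stay near compound 1, and the step of a 1.0-fold lower number from compound 1 to compound 3 (0.00 log units; within the scatter) is estimated to be none beyond the scatter. Compound 3 is therefore expected to give about 4000 nM, in a range from 1500 nM to 11000 nM.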

Compound 3, half-maximal inhibitory concentration: 4020 nM
Estimate against measurement, compound 3: 1.0-fold (0.00 log units) below, and the stated range covers the measured number.
By their numbers in this assay, from the lowest: compounds 1, 3 and 2 (each within the scatter of the next).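

Going from (4-fluorobenzyl)sulfanyl to (4-methoxybenzyl)sulfanyl on the core of compound 1 gives no change at the digits printed from compound 1 to compound 3 (within the scatter) in this assay. The earlier compounds shown here differ from each other in two places and could not isolate this position, whereas this single-place pair shows that a methoxy, with one hydrogen-bond acceptor and one more heavy atom than fluoro, can stand para to a large group without a step beyond the scatter. No separate measurement is available to explain this result.

Going by these compounds, whether an amine, a carboxylic acid or a longer chain such as butoxy at this place would also stay within the scatter remains open. Within the data shown here, it is also open whether methoxy in place of fluoro gives the same result on other compounds, as only this one pair shows the change.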